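The source may hold more compounds than are shown below. What is called first, only, known or untested is meant among the compounds shown, and "the series" means these compounds.

Compound 1 `O=C1CS/C(=N\c2c[se]c(-c3ccc(Cl)cc3)c2)N1` gives only a limit in a functional assay on SW-620 cells (Homo sapiens) for cytotoxicity, read by MTT assay, with a stated time of 72 h (a lower number here means a stronger inhibitor, a higher number a weaker inhibitor), reported as > 50000 nM. Within the data shown here, compound 2 `CN(C)c1ccc(/C=C2\S/C(=N\c3nc(-c4ccc(Cl)cc4)cs3)NC2=O)cc1` is the sole compound with a number in this assay, where compound 2 gives 200 nM. Compound 3 `O=C1N/C(=N/c2nc(-c3ccc(Cl)cc3)cs2)S/C1=C\c1ccc(F)cc1` has not yet been measured. It differs from compound 2 by fluoro in place of dimethylamino on an aromatic carbon. Among the measured compounds shown here, no measured pair shows this change, so the step is estimated as a 3.0-fold higher number from compound 2 to compound 3 (0.48 log units; beyond the scatter), leaning toward weaker inhibition yet close to the scatter. Compound 3 is therefore expected to give about 600 nM, within 150 nM to 4000 nM.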

Compound 3, half-maximal inhibitory concentration: > 50000 nM
Compound 3: a limit, no number; the forecaster's own chance of this, stated with the estimate: 5%; middle value at least 83-fold (1.92 log units) from the limit.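

In this assay, 4-fluorophenyl in place of 4-(dimethylamino)phenyl gives an at least 250-fold higher number from compound 2 to compound 3 (2.39 log units; beyond the scatter), so this single change on the aromatic ring decides whether any number can be read at all. For compound 3 the value is a limit and not a number, so the step has a floor but no measured size: the limit of > 50000 nM in this assay, at which 2 of the 3 values shown sit. The compounds shown leave open whether a methoxy group or a smaller amine such as methylamino at this place would keep the potency of compound 2. They also leave open how much of that potency depends on the dimethylamino group itself rather than on any group other than fluoro.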